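The source may report more compounds than this note shows. Statements on the series, on what has been measured and on what is new or still open speak of the compounds shown alone.

Compounds in the series:
- compound 1 `COc1ccccc1OS(=O)(=O)c1ccc(N2CCN(C)C2=O)cc1`: 21000 nM
- compound 2 `CN1CCN(c2ccc(S(=O)(=O)Oc3cccc(I)c3)cc2)C1=O`: 400 nM
- compound 3 `CCCN1CCN(c2ccc(S(=O)(=O)Oc3ccccc3OC)cc2)C1=O`: not yet measured

In a functional assay on M21 cells (Homo sapiens) for antiproliferative activity, read by sulforhodamine B assay, with a stated time of 48 h (a lower number here means a stronger inhibitor, a higher number a weaker inhibitor), compound 1 has the higher of the two numbers, at 21000 nM. Compound 3 differs from it by ethyl in place of hydrogen on a saturated chain carbon bound to an amide-type nitrogen in a ring, which takes methyl to propyl. For the measured compounds named here, the only measured step, a 53-fold lower number from compound 1 to compound 2 (1.72 log units; beyond the scatter), is large, but it is 3-iodophenyl in place of 2-methoxyphenyl on an oxygen, a change compound 3 does not share. Going by the values given here, no measured step covers the propyl change, so no shift beyond the scatter is expected in this assay. The expected change is a 1.4-fold lower number from compound 1 to compound 3 (0.15 log units; within the scatter). For compound 3 the estimated value is 15000 nM, with an expected range of 5000 nM to 45000 nM.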

Compound 3, half-maximal inhibitory concentration: > 100000 nM
Compound 3: a limit, no number; the forecaster's own chance of this, stated with the estimate: 15%; at least 6.6-fold (0.82 log units) between middle value and limit.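

In this assay compound 3 gives > 100000 nM, which is a limit of the assay and not a number. On the saturated chain carbon bound to an amide-type nitrogen in a ring, methyl to propyl is not a silent change with the 2-methoxyphenyl group in place: the step is an at least 4.7-fold higher number from compound 1 to compound 3 (0.67 log units; beyond the scatter). Its full size cannot be read, and the value it rests on is a limit: the limit of > 100000 nM in this assay, at which 1 of the 3 values shown sits.

From the compounds shown here alone, whether an ethyl or a 2-hydroxyethyl chain on that nitrogen would stay nearer compound 1 remains open. So does whether propyl has the same effect with 3-iodophenyl in place of 2-methoxyphenyl.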